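A Tetrazole Swap on the Triazole Chain Carbon

The source may report more compounds than this note shows. Statements on the series, on what has been measured and on what is new or still open speak of the compounds shown alone.

Among the measured compounds shown here, compound 1 `CC(C)C(c1nnc[nH]1)c1ccc(-c2ccc3cccc(F)c3c2)[nH]c1=O` is tested in an ADME assay on microsomes from liver (Homo sapiens) for metabolic stability (on this read-out higher numbers stand for a longer-lived compound and lower numbers for a shorter-lived compound), and gives 0.905 h, the highest of the three numbers known here. Compound 2 `CC(C)NC(=O)CC(c1ccc(-c2ccc3cccc(F)c3c2)[nH]c1=O)C(C)C` gives 0.32 h in this assay, and compound 3 `CC(C)[C@H](C[C@H]1CCNC1=O)c1ccc(-c2ccc3cccc(F)c3c2)[nH]c1=O` gives 0.257 h. For the measured compounds named here, only one measured step bears on the new compound: a 2.8-fold lower number from compound 1 to compound 2 (0.45 log units; beyond the scatter), a change at the same chain carbon that replaced the triazole with a longer, non-aromatic group. Compound 4 `CC(C)C(Cc1nnn[nH]1)c1ccc(-c2ccc3cccc(F)c3c2)[nH]c1=O` keeps an aromatic azole there, but one carbon further out, with (1H-tetrazol-5-yl)methyl in place of 4H-1,2,4-triazol-3-yl on a saturated chain carbon bound to an aromatic carbon and a saturated chain carbon. Going by the values given here, because the only comparable step, a 2.8-fold lower number from compound 1 to compound 2 (0.45 log units; beyond the scatter), was modest and moved a more different group, a smaller drop, near the scatter, is expected for compound 4, namely a 1.5-fold lower number from compound 1 to compound 4 (0.18 log units; within the scatter). Compound 4 is therefore estimated at 0.6 h, within 0.3 h to 1.2 h.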

Compound 4, half-life: > 3 h
Compound 4: a limit, no number (the forecaster's own chance of this, stated with the estimate: 5%); middle value at least 5.0-fold (0.69 log units) from the limit.
By their numbers in this assay, from the lowest: compounds 3 and 2 (each within the scatter of the next); then compound 1. At a limit, above all of these: compound 4.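

Putting (1H-tetrazol-5-yl)methyl in place of 4H-1,2,4-triazol-3-yl on this saturated chain carbon brings an at least 3.3-fold higher number from compound 1 to compound 4 (0.52 log units; beyond the scatter). Set against isopropylcarbamoyl, 1H-tetrazol-5-yl brings an at least 9.3-fold higher number from compound 2 to compound 4 (0.97 log units; beyond the scatter), so changes at this place can raise the half-life as well as lower it. Compound 4 stands at a limit, not a number: the limit of > 3 h in this assay, at which 1 of the 4 values shown sits.

From the compounds shown here alone, how far compound 4 lies past that limit stays open. Also open, going by these compounds, is whether the gain follows the tetrazole ring or the added carbon, which a (4H-1,2,4-triazol-3-yl)methyl group or a carboxylic acid on the same chain could help separate.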